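The source may hold more compounds than are shown below. What is called first, only, known or untested is meant among the compounds shown, and "the series" means these compounds.

Of the compounds shown here, two have so far been tested in an ADME assay on BHK cells (Mesocricetus auratus) for cytotoxicity, read by MTT assay, with a stated time of 96 h; a higher number here means that more compound is tolerated, a lower number that less compound is tolerated. Compound 1 `COc1ccc(-c2nc3cc(C(F)(F)F)ccc3[nH]2)c(N)c1` reaches only the assay limit, >= 100000 nM, which is a limit and not a number. Among the measured compounds shown here, compound 2 `CCN(CC)CC(=O)Nc1ccc(-c2nc3cc(C(F)(F)F)ccc3n2C)cc1` gives 16000 nM in this assay, the only number among the values shown. The other value is a limit, (the limit of >= 100000 nM in this assay, at which 1 of the 2 values shown sits). Compound 3 `CCC(=O)Nc1ccc(-c2nc3cc(C(F)(F)F)ccc3n2C)cc1` has not yet been measured. It differs from compound 2 by a single change: methyl in place of diethylamino on a saturated chain carbon bound to a carbonyl carbon. For the measured compounds named here, no step between two measured compounds is available to guide this change, so the size of the step is open. A modest shift toward more compound being tolerated is expected, with the step expected to be a 1.6-fold higher number from compound 2 to compound 3 (0.19 log units; within the scatter), though an outcome within the usual scatter would not surprise. Compound 3 is expected to give about 25000 nM in this assay, with a range from 8000 nM to 80000 nM.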

Compound 3, half-maximal cytotoxic concentration: > 100000 nM
Compound 3 ended at the assay's limit; the forecaster's own chance of this, stated with the estimate: 20%; at least 4.0-fold (0.60 log units) between middle value and limit.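

In this assay, among the compounds shown here, methyl in place of diethylamino on a saturated chain carbon bound to a carbonyl carbon gives an at least 6.2-fold higher number from compound 2 to compound 3 (0.79 log units; beyond the scatter) and so shows that this one change can move the read-out beyond the scatter, which the earlier compounds could not show. Compound 2, with its diethylamino group, is the only compound shown that gives a number in this assay and not a limit. The step has no upper end, because compound 3 stands at a limit and not at a number: the limit of > 100000 nM in this assay, at which 1 of the 3 values shown sits.

Where a smaller amine such as dimethylamino, a ring amine such as piperidine, or a longer carbon chain would fall at this place stays open. Going by these compounds, it also stays open whether the same change would hold on another core, since compound 1 differs from the others in more than one place.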